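Two analogues with a changed aryl group and a third to come

The compounds below may be only part of what the source reports. "The series", "measured", "known", "first", "only" and "open" are said of these compounds alone.

Within the data shown here, compound 2 `COc1ccccc1C1C(C#N)=C(N)N(c2ccc(S(N)(=O)=O)cc2)C2=C1C(=O)CCC2` gives 0% in a functional assay on Ehrlich cells (Mus musculus) for antiproliferative activity, read by trypan blue exclusion, with a stated time of 2 h, tested at 50 ug/mL (a higher number here means a stronger effect of the compound at the concentration tested, a lower number a weaker effect), the lower of the two numbers known; compound 1 `N#CC1=C(N)N(c2ccc(S(N)(=O)=O)cc2)C2=C(C(=O)CCC2)C1c1ccccc1` gives 40%. Among the measured compounds shown here, the single measured step, a number 40 percentage points lower from compound 1 to compound 2 (beyond the scatter), came from a methoxy in place of hydrogen on an aromatic carbon. Compound 3 `N#CC1=C(N)N(c2ccc(S(N)(=O)=O)cc2)C2=C(C(=O)CCC2)C1c1ccc(Cl)cc1Cl` has not yet been measured; it differs from compound 2 by 2,4-dichlorophenyl in place of 2-methoxyphenyl on a saturated ring carbon. For the measured compounds named here, that one step shows only that a methoxy group removed the activity of compound 1; nothing measured shows what the dichlorophenyl does. Compound 3 is therefore expected to show a modest rise, a number 20 percentage points higher from compound 2 to compound 3 (beyond the scatter), with an estimate of 20% in this assay, between 0% and 45%.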

Compound 3, a percentage reported as activity, at one concentration (the size of the read-out at that concentration, not a potency): 65%
Compound 3: the middle estimate sits 45 percentage points below what was measured, outside the stated range (above it).
By their numbers in this assay, from the lowest: compound 2; then compound 1; then compound 3.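

On the saturated ring carbon, the earlier compounds had shown only a loss from substituting the phenyl; with 2,4-dichlorophenyl in place of phenyl, the read-out in this assay instead rises, a number 25 percentage points higher from compound 1 to compound 3 (beyond the scatter). Exchanging 2-methoxyphenyl for 2,4-dichlorophenyl gives a number 65 percentage points higher from compound 2 to compound 3 (beyond the scatter), so a substituted phenyl at this place does not in itself remove the activity. No evidence is available that accounts for this difference. The compounds shown leave open whether both chlorine atoms are needed for the rise, as a 4-chlorophenyl or 2-chlorophenyl group would show. From the compounds shown here alone, how a pyridyl ring would read at this place also remains open.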